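Compound 3 to compound 4: hydroxy on the methyl

This account rests on a few compounds, and the source may have more. Where it says the series, first, only, none or still open, it means among the compounds named here.

In a functional assay on the whole organism with Rattus norvegicus as the target (on this read-out lower numbers stand for an effect already at smaller amounts and higher numbers for an effect only at larger amounts of compound), compound 3 (`CCOCCOC(=O)C(=O)Nc1nc(-c2cc(C)on2)cs1`) stands at 2 mg/kg as the higher of two numbers. Compound 1 (`CCOCCOC(=O)C(=O)Nc1nc(-c2cc(COC)no2)cs1`) gives 0.7 mg/kg as the other number. Compound 2 (`CCOCCOC(=O)C(=O)Nc1nc(-c2conc2C)cs1`) shows > 100 mg/kg as a limit of the assay and not a number.

Compound 4 (`CCOCCOC(=O)C(=O)Nc1nc(-c2cc(CO)on2)cs1`) differs from compound 3 by hydroxy in place of hydrogen on a saturated chain carbon bound to an aromatic carbon in a methyl to hydroxymethyl change, giving 5-(hydroxymethyl)-1,2-oxazol-3-yl. Going by the values given here, no measured step isolates this change. The nearest is modest (a 2.9-fold higher number from compound 1 to compound 3 (0.46 log units; beyond the scatter)) and replaces 3-(methoxymethyl)-1,2-oxazol-5-yl with 5-methyl-1,2-oxazol-3-yl. Two large steps (an at least 140-fold higher number from compound 1 to compound 2 (2.15 log units; beyond the scatter) and an at least 50-fold lower number from compound 2 to compound 3 (1.69 log units; beyond the scatter)) run through the limit of compound 2 and its 3-methyl-1,2-oxazol-4-yl, which compound 4 does not carry. Resting on the modest step, no change beyond the scatter is expected (no change at the digits printed from compound 3 to compound 4 (within the scatter)). For compound 4 the estimated value is 2 mg/kg with an expected range from 0.5 mg/kg to 10 mg/kg in this read-out.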

Compound 4, dose for half-maximal effect: 14 mg/kg
Beside the measured number, compound 4's estimate is 7.0-fold (0.85 log units) below it; measured number outside the range, above it.
By their numbers in this assay, from the lowest: compound 1; then compound 3; then compound 4. At a limit, above all of these: compound 2.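

In this assay, going by these compounds alone, hydroxy on the methyl of 5-methyl-1,2-oxazol-3-yl has a readable effect, and this is the first step that isolates this place: a 7.0-fold higher number from compound 3 to compound 4 (0.85 log units; beyond the scatter). The whole-group exchange gives a larger step, a 20-fold higher number from compound 1 to compound 4 (1.30 log units; beyond the scatter), but it changes more than this one place. The step of an at least 7.1-fold lower number from compound 2 to compound 4 (0.85 log units; beyond the scatter) is only a bound, since compound 2 carries a limit and not a number: the limit of > 100 mg/kg in this assay, at which 1 of the 4 values shown sits.

Going by these compounds, it remains open whether the higher number follows from the hydroxy alone or from any group on this carbon. An aminomethyl or a carboxylic acid in this place would test that.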